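Trifluoromethoxy in Place of Methylsulfonyl on a Hydrazone Aryl

The source may hold more compounds than are shown below. What is called first, only, known or untested is meant among the compounds shown, and "the series" means these compounds.

Compound 1 `Cn1c(=O)c(=O)n(C2CCCC2)c2nc(N/N=C/c3ccc(S(C)(=O)=O)cc3)ncc21`: 26600 nM
Compound 2 `Cn1c(=O)c(=O)n(C2CCCC2)c2nc(N/N=C/c3cccc(O)c3)ncc21`: 36300 nM
Compound 3 `Cn1c(=O)c(=O)n(C2CCCC2)c2nc(N/N=C/c3ccc(F)cc3Br)ncc21`: 9250 nM

These three compounds share one core and differ only in the aryl group on the carbon with a double bond to nitrogen, measured in a functional assay on PC-3 cells (Homo sapiens) for antiproliferative activity, read by MTT assay; on this read-out higher numbers stand for weaker inhibition and lower numbers for stronger inhibition. Compound 1 holds the second highest number of the three; a 1.4-fold higher number from compound 1 to compound 2 (0.14 log units; within the scatter), whereas a 2.9-fold lower number from compound 1 to compound 3 (0.46 log units; beyond the scatter). Compound 4 `Cn1c(=O)c(=O)n(C2CCCC2)c2nc(N/N=C/c3ccc(OC(F)(F)F)cc3)ncc21` keeps the aryl ring of compound 1 and changes one group: trifluoromethoxy in place of methylsulfonyl on an aromatic carbon. Going by the values given here, no measured step tests this exact exchange; the measured steps replaced the whole aryl and gave at most a modest shift. The number for compound 4 is therefore expected close to that of compound 1, with a 1.3-fold lower number from compound 1 to compound 4 (0.12 log units; within the scatter) likely within or barely beyond the scatter. Compound 4 is estimated at 20000 nM, ranging from 7000 nM to 55000 nM.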

Compound 4, half-maximal inhibitory concentration: 7180 nM
For compound 4 the middle estimate is 2.8-fold (0.44 log units) above the measured one, and the stated range covers the measured number.
By their numbers in this assay, from the lowest: compounds 4 and 3 (each within the scatter of the next); then compounds 1 and 2 (each within the scatter of the next).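

In this assay, going by these compounds alone, changing only one group on the aryl ring gives a 3.7-fold lower number from compound 1 to compound 4 (0.57 log units; beyond the scatter) and so shows that this single exchange is enough to move the number beyond the scatter. The earlier compounds shown here could not show this, since each step between them replaced the whole aryl group. Nothing measured here gives a reason for the drop. The compounds shown leave open how an amine, a carboxylic acid or a longer alkoxy chain on this same aromatic carbon would read in this assay.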